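The source may hold more compounds than are shown below. What is called first, only, known or untested is meant among the compounds shown, and "the series" means these compounds.

Compound 1 `COC(=O)N1CCN([C@H]2CC[C@H](Nc3ncnn4ccc([C@H](C)CC(N)=O)c34)CC2)CC1` and compound 2 `CC(=O)N1CCN([C@H]2CC[C@H](Nc3ncnn4ccc(C(C)C)c34)CC2)CC1` share one core and differ at two places. In an ADME assay on a cell-free system (plasma, Homo sapiens) for protein binding, using equilibrium dialysis (a higher number here means a larger unbound share of the compound, a lower number a smaller unbound share), compound 1 gives 0.37, and compound 2 gives 0.24; the two numbers lie within the scatter of each other, so neither can be set above the other. Compound 3 `CC(=O)N1CCN([C@H]2CC[C@H](Nc3ncnn4ccc(C5CCOCC5)c34)CC2)CC1` changes compound 2 in one place, (oxan-4-yl in place of isopropyl on an aromatic carbon). Among the compounds with values here, no measured step guides this change, so the expectation rests on compound 2 alone: compound 3 is expected to show a modest step upward in this assay, a 1.6-fold higher number from compound 2 to compound 3 (0.20 log units; within the scatter), beyond the scatter. Compound 3 is thus estimated at 0.38, in the range 0.22 to 0.6.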

Compound 3, unbound fraction in the Homo sapiens assay: 0.48
Compound 3: middle estimate off by 1.3-fold (0.10 log units), on the low side; measured number inside the range.
By their numbers in the Homo sapiens assay, from the lowest: compounds 2, 1 and 3 (each within the scatter of the next).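

In the Homo sapiens assay, the first change made in one place, oxan-4-yl in place of isopropyl on an aromatic carbon, gives a 2.0-fold higher number from compound 2 to compound 3 (0.30 log units; within the scatter), so this carbon carries the larger ring without a shift past the scatter. In a physicochemical assay for solubility, in phosphate buffer, at pH 7.4 (on this read-out higher numbers stand for higher solubility and lower numbers for lower solubility), compound 2 gives > 952000 nM, which is a limit of the assay and not a number. In the physicochemical assay compound 3 gives > 1000000 nM, also a limit, so the step between the two cannot be read.

As far as these compounds go, whether an amine or a carboxylic acid on this aromatic carbon would move the number in the Homo sapiens assay beyond the scatter stays open.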